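Formyl to pyridin-3-yl on the ring nitrogen

The source may hold more compounds than are shown below. What is called first, only, known or untested is meant among the compounds shown, and "the series" means these compounds.

Compound 2 `Cc1c(C)c2c(c(C)c1NC=O)CC(C)(C)O2` and compound 1 `Cc1c(C)c2c(c(C)c1N)CC(C)(CSc1ccncc1)O2` share the same core. In a functional assay on the whole organism with Mus musculus as the target (a lower number here means that less compound is needed, a higher number that more compound is needed for the effect), compound 1 gives 19.9 mg/kg. Compound 2 reaches only the limit of this assay, > 100 mg/kg, so for compound 2 a limit and no number is known (the limit of > 100 mg/kg in this assay, at which 1 of the 2 values shown sits). Compound 3 `Cc1c(C)c2c(c(C)c1Nc1cccnc1)CC(C)(C)O2` is compound 2 with one change: pyridin-3-yl in place of formyl on a nitrogen on an aromatic ring. Going by the values given here, no measured pair differs in this one place, so the size of the step from compound 2 to compound 3 rests on the two values shown. Among the compounds with values here, compound 1, the only compound here with a number, also carries a pyridine ring and sits inside the range of this assay. The change is expected to lower the dose: the step of an at least 2.5-fold lower number from compound 2 to compound 3 (0.39 log units; beyond the scatter) is estimated to reach beyond the scatter. For compound 3 the estimate is 40 mg/kg, with a range from 10 mg/kg to 150 mg/kg.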

Compound 3, dose for 50% inhibition: > 50 mg/kg
Compound 3 was reported as a limit; the forecaster's own chance of this, stated with the estimate: 35%; middle value at least 1.2-fold (0.09 log units) away from the limit.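

Compound 2 stands only as a limit, > 100 mg/kg. Going by these compounds alone, compound 3 is also only a limit, > 50 mg/kg, so no step from formyl to pyridin-3-yl can be read. Left open is how far each compound lies past its limit, and whether this change shifts the dose at all.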